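The compounds below may be only part of what the source reports. "The series", "measured", "known", "first", "only" and "open" are said of these compounds alone.

Compound 1 `N/C(=N\NC(=S)N1CCSCC1)c1ccccn1`, compound 2 `Cc1ccnc(/C(N)=N/NC(=S)N2CCCCCC2)c1` and compound 3 `N/C(=N\NC(=S)N1CCOCC1)c1ccc(F)cn1` share one core and differ in the amine attached to the thiocarbonyl and in the substituent on the six-membered aromatic ring with 1 nitrogen. In a functional assay on A-375 cells (Homo sapiens) for cytotoxicity, read by MTT assay, with a stated time of 72 h, tested at 30 uM (on this read-out lower numbers stand for less inhibition of growth and higher numbers for more inhibition of growth at the one concentration tested), compound 1 gives 86%, compound 2 gives 76.5% and compound 3 gives 85.9%; the three numbers lie within the usual scatter of one another, so compound 3 stands on a par with both. Compound 4 `N/C(=N\NC(=S)N1CCOCC1)c1ccccn1` is not yet measured. It differs from compound 3 in one place: hydrogen in place of fluoro on an aromatic carbon. For the measured compounds named here, with only single-point numbers to go on and no measured pair for this change, the step from compound 3 to compound 4 is expected to stay within the scatter, roughly a number 1.9 percentage points lower from compound 3 to compound 4 (within the scatter). Compound 4 is therefore estimated at 84%, between 72% and 92%.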

Compound 4, percent growth inhibition at one concentration: 15%
Beside the measured number, compound 4's estimate is 69 percentage points above it, and the stated range ends above it.
By their numbers in this assay, from the lowest: compound 4; then compounds 2, 3 and 1 (each within the scatter of the next).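

In this assay, for the compounds shown here, hydrogen in place of fluoro on an aromatic carbon two atoms from the ring nitrogen gives a number 70.9 percentage points lower from compound 3 to compound 4 (beyond the scatter), so this position, which looked tolerant in the earlier compounds, carries a large change. With hydrogen on that carbon the amine matters too: morpholin-4-yl in place of thiomorpholin-4-yl gives a number 71 percentage points lower from compound 1 to compound 4 (beyond the scatter), so the loss appears only with morpholin-4-yl and hydrogen together. Nothing available explains this drop. As far as these compounds go, whether a chlorine atom or a methyl group on that carbon would keep the growth inhibition of compound 3 stays open. Also open, from the compounds shown here alone, is whether fluoro makes any difference alongside thiomorpholin-4-yl.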